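A few compounds are considered here, and "the series" means these few. Any claim that something is new, unique, unknown or untested is made for them only; others in the source may bear on it.

Working notes on the series. Among the measured compounds shown here, in a functional assay on the whole organism with Rattus norvegicus as the target (on this read-out higher numbers stand for an effect only at larger amounts of compound and lower numbers for an effect already at smaller amounts), compound 1 (`CCOC(=O)C(=O)Nc1cccc(OC)c1C#N`) gives 5.3 mg/kg and compound 2 (`CCOC(=O)C(=O)Nc1cccc(NC)c1C#N`) gives 0.2 mg/kg as the lower of the two numbers so far. Compound 3 (`CCNc1cccc(NC(=O)C(=O)OCC)c1C#N`) is not yet measured. It differs from compound 2 by methyl in place of hydrogen on a saturated chain carbon bound to a nitrogen on an aromatic ring. For the measured compounds named here, the only measured step that bears on this is a 27-fold lower number from compound 1 to compound 2 (1.42 log units; beyond the scatter) for methylamino in place of methoxy on an aromatic carbon. Going by the values given here, that step is large and beyond the scatter, but no measured step covers methyl to ethyl, so it sets no size for this change. A small move towards a higher number in this assay is expected, perhaps no more than the scatter, and the expected step is a 2.0-fold higher number from compound 2 to compound 3 (0.30 log units; within the scatter) on this reading. The estimate for compound 3 is 0.4 mg/kg with an expected range from 0.12 mg/kg to 1.5 mg/kg as the working figure.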

Compound 3, dose for half-maximal effect: 0.03 mg/kg
For compound 3 the middle estimate is 13-fold (1.12 log units) above the measured one, and the stated range ends above it.
By their numbers in this assay, from the lowest: compound 3; then compound 2; then compound 1.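

The added methyl on a saturated chain carbon bound to a nitrogen on an aromatic ring is not a silent change: in this assay, methylamino to ethylamino gives a step beyond the scatter (a 6.7-fold lower number from compound 2 to compound 3 (0.82 log units; beyond the scatter)). Relative to methoxy, ethylamino gives a larger step (a 180-fold lower number from compound 1 to compound 3 (2.25 log units; beyond the scatter)) than methylamino does (a 27-fold lower number from compound 1 to compound 2 (1.42 log units; beyond the scatter)), so the outcome at this position depends on the group on the nitrogen as well as on the exchange of oxygen for nitrogen. No data on the cause of either step are available.

With only methylamino and ethylamino in hand, two points do not establish a trend with chain length. Going by these compounds, whether a longer chain such as propylamino, a branched isopropylamino or a dimethylamino group continues the move towards lower numbers remains open.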